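The source may hold more compounds than are shown below. What is called first, only, known or untested is meant among the compounds shown, and "the series" means these compounds.

Measured compounds in an assay on CHO cells for positive allosteric modulation of Cystic fibrosis transmembrane conductance regulator variant F508del (Homo sapiens), using a membrane potential dye, with a stated time of 30 min, in the presence of a further agent that is not named here; on this read-out higher numbers stand for an effect only at larger amounts of compound and lower numbers for an effect already at smaller amounts:
compound 1 `CNC(=O)c1nc(Br)c(C(F)(F)F)cc1N` gives 250 nM
compound 2 `Nc1cc(C(F)(F)F)c(Br)nc1C(=O)NCCC(F)(F)F` gives 40 nM
compound 3 `Nc1cc(C(F)(F)F)c(Br)nc1C(=O)NC[C@@H](O)C(F)(F)F` gives 9 nM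

Compound 3 holds the lowest number of the three; the steps to it are a 4.4-fold lower number from compound 2 to compound 3 (0.65 log units; beyond the scatter) and a 28-fold lower number from compound 1 to compound 3 (1.44 log units; beyond the scatter), both beyond the scatter, and the step of a 6.3-fold lower number from compound 1 to compound 2 (0.80 log units; beyond the scatter) shows the trifluoroethyl chain already counts on its own.

Compound 4 `CC(C)(O)CNC(=O)c1nc(Br)c(C(F)(F)F)cc1N` differs from compound 3 by 1-hydroxy-1-methylethyl in place of 2,2,2-trifluoro-1-hydroxyethyl on a saturated chain carbon bound to an amide-type nitrogen. Going by the values given here, the hydroxy that drove the step from compound 2 to compound 3 is kept, but the trifluoromethyl that sat in every gain so far is gone and no measured step covers that exchange directly. Compound 4 is therefore expected to give a 2.8-fold higher number from compound 3 to compound 4 (0.44 log units; beyond the scatter), a modest rise in this assay, estimated at 25 nM with a range of 8 nM to 80 nM.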

Compound 4, half-maximal effective concentration: 77 nM
Beside the measured number, compound 4's estimate is 3.1-fold (0.49 log units) below it; measured number inside the range.
By their numbers in this assay, from the lowest: compound 3; then compounds 2 and 4 (each within the scatter of the next); then compound 1.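

Keeping the hydroxy does not hold the gain at this position once trifluoromethyl gives way to two methyls: an 8.6-fold higher number from compound 3 to compound 4 (0.93 log units; beyond the scatter) is the largest of the new steps. The 1-hydroxy-1-methylethyl group still counts against plain hydrogen on the saturated chain carbon, with a 3.2-fold lower number from compound 1 to compound 4 (0.51 log units; beyond the scatter) as its step. Set against 2,2,2-trifluoroethyl, it shows no separable difference, a 1.9-fold higher number from compound 2 to compound 4 (0.28 log units; within the scatter) as the exchange.

Open, on these data alone, is whether an amine, a carboxylic acid or a longer chain could stand in for the hydroxy-bearing group and what the opposite stereocentre gives. Nothing available explains these differences.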